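Carbamate Nitrogen Substituents on a Ghrelin Receptor Agonist Series

The source may hold more compounds than are shown below. What is called first, only, known or untested is meant among the compounds shown, and "the series" means these compounds.

Compound 1, `CC(C)(N)C(=O)N[C@H](COCc1ccccc1)c1nnnn1CCOC(=O)NCCO`: 3 nM
Compound 2, `CN(CCCCO)C(=O)OCCn1nnnc1[C@@H](COCc1ccccc1)NC(=O)C(C)(C)N`: 3.8 nM

Two compounds share a common core and differ only in the substituent on the carbamate nitrogen. In a functional assay on H4 cells with growth hormone secretagogue receptor type 1 (Homo sapiens) as the target, read by FLIPR (on this read-out higher numbers stand for an effect only at larger amounts of compound and lower numbers for an effect already at smaller amounts), compound 1 gives 3 nM, and compound 2 gives 3.8 nM. Compound 2 carries the highest of the two numbers, but its nearest neighbour is compound 1, and the step of a 1.3-fold higher number from compound 1 to compound 2 (0.10 log units; within the scatter) lies within the scatter, so the two cannot be ordered.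

Compound 3, `CC(C)(N)C(=O)N[C@H](COCc1ccccc1)c1nnnn1CCOC(=O)N1CC[C@@H](O)C1`, has not yet been measured in this assay. Its change from compound 2 is 3-hydroxypyrrolidin-1-yl in place of (4-hydroxybutyl)(methyl)amino on a carbonyl carbon. Within the data shown here, the one measured step that bears on this position is a 1.3-fold higher number from compound 1 to compound 2 (0.10 log units; within the scatter), where the substituent on that same carbonyl carbon was exchanged without a change beyond the scatter. On this basis no step beyond the scatter is expected in this assay for compound 3, in either direction. The estimated step of a 1.1-fold higher number from compound 2 to compound 3 (0.02 log units; within the scatter) is accordingly small. Compound 3 is therefore expected to give about 4 nM, with a range from 1.5 nM to 11 nM.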

Compound 3, half-maximal effective concentration: 1 nM
The estimate for compound 3 lay 4.0-fold (0.60 log units) above the measured number; the measured number lies below the stated range.
By their numbers in this assay, from the lowest: compound 3; then compounds 1 and 2 (each within the scatter of the next).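

The substituent on this carbonyl carbon can change the result in this assay, a point the earlier pair did not show: placing 3-hydroxypyrrolidin-1-yl there gives a 3.8-fold lower number from compound 2 to compound 3 (0.58 log units; beyond the scatter) and also a 3.0-fold lower number from compound 1 to compound 3 (0.48 log units; beyond the scatter) in the same direction. The two groups without a ring, (2-hydroxyethyl)amino and (4-hydroxybutyl)(methyl)amino, still cannot be ordered, while the group with the five-membered ring stands apart from both, a pattern that rests on these three compounds alone. Nothing shown here accounts for this shift.

As far as these compounds go, it remains open whether the lower number goes with the ring itself or with the hydroxyl on it, a question that an unsubstituted pyrrolidin-1-yl group on the same carbonyl carbon would address. Also open, from the compounds shown here alone, is how the opposite configuration at the defined stereocentre, a six-membered 4-hydroxypiperidin-1-yl ring or an amine in place of the hydroxyl would read in this assay at this position.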